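Methoxy addition on the bromo core: expected cytotoxicity

The compounds below may be only part of what the source reports. "The series", "measured", "known", "first", "only" and "open" are said of these compounds alone.

Compound 1 `Cc1cc(C(=O)c2ccccc2)ccc1OCC(=O)Nc1nc(-c2ccccc2)cs1` and compound 3 `Cc1cc(C(=O)c2cccc(Br)c2)ccc1OCC(=O)Nc1nc(-c2ccccc2)cs1` share a core that differs in one place only, (bromo in place of hydrogen on an aromatic carbon), which gave a 1.1-fold higher number from compound 1 to compound 3 (0.02 log units; within the scatter) in a functional assay on Ehrlich cells (Mus musculus) for cytotoxicity, read by LDH release, with a stated time of 48 h; a higher number here means a weaker inhibitor, a lower number a stronger inhibitor. In this assay compound 1 gives 24500 nM and compound 3 gives 25900 nM. Compound 2 `COc1ccc(-c2csc(NC(=O)COc3ccc(C(=O)c4ccccc4)cc3C)n2)cc1` carries the change methoxy in place of hydrogen on an aromatic carbon on the core of compound 1, and in this assay compound 2 gives 28600 nM, a step of a 1.2-fold higher number from compound 1 to compound 2 (0.07 log units; within the scatter). Compound 4 `COc1ccc(-c2csc(NC(=O)COc3ccc(C(=O)c4cccc(Br)c4)cc3C)n2)cc1` carries the same change on the core of compound 3, (methoxy in place of hydrogen on an aromatic carbon), at a place described in the same words as for compound 2. Within the data shown here, the step from compound 3 to compound 4 is expected to be a 1.2-fold higher number from compound 3 to compound 4 (0.06 log units; within the scatter) because the single earlier instance of this change gave a 1.2-fold higher number from compound 1 to compound 2 (0.07 log units; within the scatter). Compound 4 is therefore estimated at 30000 nM, with a range expected from 15000 nM to 60000 nM.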

Compound 4, half-maximal inhibitory concentration: 40600 nM
Compound 4: middle estimate off by 1.4-fold (0.13 log units), on the low side; the measured number falls inside the stated range.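

In this assay, phenyl to 4-methoxyphenyl on the bromo core gave a 1.6-fold higher number from compound 3 to compound 4 (0.20 log units; within the scatter), and this step agrees with the earlier instance of the change: the same change on two cores in this assay, a 1.2-fold higher number (0.07 log units; within the scatter) from compound 1 to compound 2 and a 1.6-fold higher number (0.20 log units; within the scatter) from compound 3 to compound 4, 1.3-fold (0.13 log units) apart, within the scatter of two such steps The bromo change, carried onto the methoxy core, gave a 1.4-fold higher number from compound 2 to compound 4 (0.15 log units; within the scatter), and it agrees with its earlier instance in the same way: the same change on two cores in this assay, a 1.1-fold higher number (0.02 log units; within the scatter) from compound 1 to compound 3 and a 1.4-fold higher number (0.15 log units; within the scatter) from compound 2 to compound 4, 1.3-fold (0.13 log units) apart, within the scatter of two such steps Both changes therefore carry between these two cores without a detectable difference, but every step lies within the scatter, so this shows neither a real effect of either group nor any rule beyond these four compounds.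

Open, as far as these compounds go, is whether another group at this place, such as an amine or a carboxylic acid, would give a step beyond the scatter. Also open, from the compounds shown here alone, is whether such a step would carry from one core to the other.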